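Amine substituent variation at the methylene of compound 3

This account rests on a few compounds, and the source may have more. Where it says the series, first, only, none or still open, it means among the compounds named here.

Measured compounds, with their numbers in an assay on isolated protein for binding affinity to Gonadotropin-releasing hormone receptor (Homo sapiens); on this read-out lower numbers stand for stronger inhibition and higher numbers for weaker inhibition:
- compound 1 `CCN(CC)CCN(C)Cc1c(C(C)(C)C)nc2n(Cc3ccccc3F)c(C)c(-c3cccc(OC)c3)c(=O)n12`, compound 1 gives 260 nM
- compound 2 `COc1cccc(-c2c(C)n(Cc3ccccc3F)c3nc(C(C)(C)C)c(CN(C)Cc4ccccc4)n3c2=O)c1`, compound 2 gives 72 nM
- compound 3 `COC(=O)C(C)(C)c1nc2n(Cc3ccccc3F)c(C)c(-c3cccc(OC)c3)c(=O)n2c1CN(C)Cc1ccccc1`, compound 3 gives 59 nM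

Compound 3 has the lowest number of the three. Its nearest neighbour is compound 2, and the two lie within the scatter of each other, so no order between them can be read. Compound 1 is the furthest, and the gap to it is beyond the scatter.

Compound 4 `COC(=O)C(C)(C)c1nc2n(Cc3ccccc3F)c(C)c(-c3cccc(OC)c3)c(=O)n2c1CN1CCC(c2ccccc2)CC1` differs from compound 3 in one place: 4-phenylpiperidin-1-yl in place of benzyl(methyl)amino on a saturated chain carbon bound to an aromatic carbon.

Two measured steps exist. The step of a 3.6-fold lower number from compound 1 to compound 2 (0.56 log units; beyond the scatter) is the only one that touches the amine substituent, and it shows that exchanging a (diethylamino)methyl chain for a phenyl there moved the number by a modest amount. The step of a 1.2-fold lower number from compound 2 to compound 3 (0.09 log units; within the scatter) sits elsewhere on the core and stayed within the scatter. Going by the values given here, no measured step closes the amine into a ring, so nothing shows what joining the nitrogen into a 4-phenylpiperidin-1-yl ring does. The phenyl is kept in compound 4, so the expected change from compound 3 to compound 4 is a 1.0-fold higher number from compound 3 to compound 4 (0.01 log units; within the scatter), which is within the scatter. Compound 4 is therefore estimated to give 60 nM in this assay, with a range from 20 nM to 180 nM.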

Compound 4, inhibition constant: 5100 nM
For compound 4 the middle estimate is 85-fold (1.93 log units) below the measured one; the whole stated range lies below it.
By their numbers in this assay, from the lowest: compounds 3 and 2 (each within the scatter of the next); then compound 1; then compound 4.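

In this assay, going by these compounds alone, 4-phenylpiperidin-1-yl in place of benzyl(methyl)amino on a saturated chain carbon bound to an aromatic carbon gives a large step (an 86-fold higher number from compound 3 to compound 4 (1.94 log units; beyond the scatter)), much larger than the only earlier step at this amine substituent (a 3.6-fold lower number from compound 1 to compound 2 (0.56 log units; beyond the scatter)). Compound 1, compound 2 and compound 3 all carry an open-chain amine, so only compound 4 shows that keeping a phenyl and the same hydrogen-bond donor and acceptor counts is not enough to hold the number at this position. No measurement available on the series accounts for the size of this step.

Going by these compounds, it remains open whether the higher number goes with the piperidine ring itself or with how the phenyl is attached to it; a plain piperidin-1-yl, a 4-benzylpiperidin-1-yl and an open-chain N-methyl-2-phenylethylamine at the same place would help separate these options. On these data alone, it also remains open whether the same step would appear on the core of compound 2, which carries tert-butyl where compound 3 carries the methoxycarbonyl-bearing group.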